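Acetamido in Place of Cyano: a Lipophilicity Step Repeated

The compounds below may be only part of what the source reports. "The series", "measured", "known", "first", "only" and "open" are said of these compounds alone.

Measured so far in a physicochemical assay for lipophilicity, at pH 7.4; on this read-out lower numbers stand for lower lipophilicity and higher numbers for higher lipophilicity:
compound 1, `Cc1cc(COc2ccccc2C#N)nc(-c2ccccn2)n1`, gives 2.7
compound 2, `Cc1cc(COc2ccc(C#N)cc2)nc(-c2ccccn2)n1`, gives 2.6
compound 3, `CC(=O)Nc1ccccc1OCc1cc(C)nc(-c2ccccn2)n1`, gives 1.6

Compound 1 and compound 2 have the same atoms joined differently; the difference between the two cores is not broken down here, and their two values lie within the scatter of each other. From compound 1 to compound 3 the change is acetamido in place of cyano on an aromatic carbon, and it made a step of a number 1.10 log units lower from compound 1 to compound 3 (beyond the scatter). Compound 4, `CC(=O)Nc1ccc(OCc2cc(C)nc(-c3ccccn3)n2)cc1`, is not yet measured. It stands to compound 2 as compound 3 stands to compound 1: acetamido in place of cyano on an aromatic carbon. This is the same kind of change, not the same one: in compound 3 the acetamido sits ortho to a large group, in compound 4 para to a large group. The expected step is a number 1.10 log units lower from compound 2 to compound 4 (beyond the scatter), set beside the earlier one. Resting on compound 2 at 2.6 and on the step of a number 1.10 log units lower from compound 1 to compound 3 (beyond the scatter), the value of compound 4 in this assay is estimated at 1.5, between 1.2 and 1.9.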

Compound 4, distribution coefficient: 1.9
Beside the measured number, compound 4's estimate is 0.40 log units below it; the range from low to high includes it.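

Within this assay acetamido in place of cyano on an aromatic carbon gave a number 0.70 log units lower from compound 2 to compound 4 (beyond the scatter) after a number 1.10 log units lower from compound 1 to compound 3 (beyond the scatter) in the other core, so the direction carried over while the size did not repeat exactly. These two pairs show agreement in direction only; they fix no general size for the step, and the acetamido of compound 4, para to a large group, does not sit where that of compound 3 sits. Nothing available bears on why the two steps differ in size. 

As far as these compounds go, whether an amine or a carboxylic acid on the same aromatic carbon would move the number the same way in both cores stays open. So does whether the acetamido step would hold on any core beyond these two.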